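The compounds below may be only part of what the source reports. "The series", "measured", "known", "first", "only" and "open" are said of these compounds alone.

Compound 1 `COc1ccc(-c2cc(-c3ccc(OC)cc3)on2)cc1` was tested in a functional assay on HeLa cells (Homo sapiens) for antiproliferative activity, read by cell counting, with a stated time of 5 days; on this read-out lower numbers stand for stronger inhibition and higher numbers for weaker inhibition. In this assay compound 1 gives > 100000 nM, which is a limit of the assay rather than a measured number. Compound 2 `CCc1c(-c2ccc(OC)cc2)noc1-c1ccc(OC)cc1` carries an ethyl in place of hydrogen on an aromatic carbon of the shared core. In this assay compound 2 gives > 100000 nM, again a limit. Among the compounds with values here, the step from compound 1 to compound 2 is therefore a step that the two limits leave unreadable from compound 1 to compound 2, and the only evidence on the measured steps is the limit of > 100000 nM in this assay, at which 2 of the 2 values shown sit. Compound 3 `COc1ccc(-c2cc(-c3ccc([N+](=O)[O-])cc3)on2)cc1` differs from compound 1 in one place: nitro in place of methoxy on an aromatic carbon. Within the data shown here, no measured step exchanges one group for another on that ring, and the single measured step has no readable size, so nothing here points to compound 3 moving beyond a limit. Compound 3 is expected to give about 150000 nM, within 30000 nM to 600000 nM. This estimate means an expected step that the limit leaves unreadable from compound 1 to compound 3.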

Compound 3, half-maximal inhibitory concentration: > 100000 nM
Compound 3 was reported as a limit (the forecaster's own chance of this, stated with the estimate: 75%); the middle value lies beyond the limit too.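

Compound 1 and compound 3 are both known only as limits of the assay, so the step between them cannot be read. The compounds shown leave open whether any change on the shared core would give a true measured number in this assay.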